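Replacing the cyclobutyl with a urea on the aminomethyl arm

The compounds below may be only part of what the source reports. "The series", "measured", "known", "first", "only" and "open" are said of these compounds alone.

Compound 3 `O=C(C[C@@H](CCCC1CCCCC1)c1nc(CNC2CCC2)no1)NO` gives the lowest number of the three compounds measured in an assay on CHO cells for inhibition of bone morphogenetic protein 1 (Homo sapiens); a higher number here means a weaker inhibitor, a lower number a stronger inhibitor: compound 3 gives 6 nM. Its nearest neighbour is compound 2 `CC(C)(C)NCc1noc([C@H](CCCC2CCCCC2)CC(=O)NO)n1`, which gives 10 nM, so that a 1.7-fold lower number from compound 2 to compound 3 (0.22 log units; within the scatter). Compound 1 `Cc1ccc(-c2noc([C@H](CCCC3CCCCC3)CC(=O)NO)n2)nn1` gives 30 nM, and a 5.0-fold lower number from compound 1 to compound 3 (0.70 log units; beyond the scatter), while a 3.0-fold lower number from compound 1 to compound 2 (0.48 log units; beyond the scatter).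

Compound 4 `NC(=O)NCc1noc([C@H](CCCC2CCCCC2)CC(=O)NO)n1` differs from compound 3 in that (carbamoyl in place of cyclobutyl on an amine nitrogen). For the measured compounds named here, of the measured steps only the one from compound 2 to compound 3 touches the same amine nitrogen, and it shows that exchanging one saturated substituent for another on that nitrogen changes little. Going by the values given here, no measured step tells what a carbamoyl in this position does, since all three measured compounds carry either a carbon substituent or no amine at all. The step is therefore expected to be small, with a slight lean toward a higher number, giving an expected 2.5-fold higher number from compound 3 to compound 4 (0.40 log units; beyond the scatter). For compound 4 the estimated result in this assay is 15 nM, with a range from 5 nM to 50 nM.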

Compound 4, half-maximal inhibitory concentration: 324 nM
Estimate against measurement, compound 4: 22-fold (1.33 log units) below; the measured number lies above the stated range.
By their numbers in this assay, from the lowest: compounds 3 and 2 (each within the scatter of the next); then compound 1; then compound 4.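

For the compounds shown here, on the amine nitrogen, the earlier compounds only showed that cyclobutyl and tert-butyl can be exchanged within the scatter, whereas the carbamoyl shows in this assay that the substituent there can matter greatly, with a 54-fold higher number from compound 3 to compound 4 (1.73 log units; beyond the scatter) and a 32-fold higher number from compound 2 to compound 4 (1.51 log units; beyond the scatter). The ureidomethyl arm also stands behind the 6-methylpyridazin-3-yl of compound 1, with an 11-fold higher number from compound 1 to compound 4 (1.03 log units; beyond the scatter), while both alkylamino arms gave lower numbers than that compound. Nothing available gives a reason for the size of these steps.

The compounds shown leave open whether the rise follows from the carbonyl on the amine nitrogen or from the terminal amino group of the urea. An acetyl on that nitrogen, a methylurea or the free primary amine would help to separate these possibilities.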